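This account rests on a few compounds, and the source may have more. Where it says the series, first, only, none or still open, it means among the compounds named here.

Of the compounds shown here, two that share one core have been measured in a functional assay on HL-60 cells (Homo sapiens) for antiproliferative activity, read by MTT assay, with a stated time of 72 h; a higher number here means a weaker inhibitor, a lower number a stronger inhibitor. Among the compounds with values here, compound 1 `NC1=NC2(CCSCC2)N(OCCCOc2cc(Cl)c(Cl)cc2Cl)C(N)=N1` gives 730 nM, and compound 2 `NC1=NC2(CCSCC2)N(OCCCOc2ccccc2Cl)C(N)=N1` gives 390 nM, so compound 2 stands within the scatter of compound 1, the only other compound with a number. Compound 3 `NC1=NC2(CCSCC2)N(OCCCOc2cccc(Br)c2)C(N)=N1` has not yet been measured. It differs from compound 2 in one place: 3-bromophenyl in place of 2-chlorophenyl on an oxygen on a saturated carbon. Here 3-bromophenyl takes the place of 2-chlorophenyl on an oxygen on a saturated carbon. Within the data shown here, only one measured step bears on this change, the replacement of 2,4,5-trichlorophenyl by 2-chlorophenyl on that same oxygen, and it came to a 1.9-fold lower number from compound 1 to compound 2 (0.27 log units; within the scatter). Among the measured compounds shown here, no measured compound carries 3-bromophenyl, so that single step is the only guide available. A step beyond the scatter is therefore not expected in this assay, and no direction can be argued from the data. The expected change is a 1.2-fold higher number from compound 2 to compound 3 (0.06 log units; within the scatter). For compound 3 the estimated value is 450 nM, with an expected range from 170 nM to 1200 nM.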

Compound 3, half-maximal inhibitory concentration: 200 nM
For compound 3 the middle estimate is 2.3-fold (0.35 log units) above the measured one; measured number inside the range.
By their numbers in this assay, from the lowest: compounds 3, 2 and 1 (each within the scatter of the next, the first and the last beyond it).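

In this assay the exchange of 2-chlorophenyl for 3-bromophenyl on the oxygen gives a 2.0-fold lower number from compound 2 to compound 3 (0.29 log units; within the scatter) and so stays within the scatter, which means these two groups cannot be told apart by this measure. Within the data shown here, the comparison with the trichlorinated compound gives the first step in the set beyond the scatter, a 3.7-fold lower number from compound 1 to compound 3 (0.56 log units; beyond the scatter), so the group on this oxygen can shift the number, if only modestly, even though compound 2 remains within the scatter of both compound 1 and compound 3. No evidence accompanies these numbers that would explain this difference.

On these data alone, compound 2 and compound 3 differ in both the halogen and its place on the ring, so it remains open which of the two matters, a question that 3-chlorophenyl and 2-bromophenyl would separate. Also open, as far as these compounds go, is how an unsubstituted phenyl, a ring carrying an amine or a carboxylic acid, or a longer chain to the oxygen would fare in this assay on this shared core.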